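The source may hold more compounds than are shown below. What is called first, only, known or untested is meant among the compounds shown, and "the series" means these compounds.

Measured values in an ADME assay on HEK293 cells (Homo sapiens) for cytotoxicity, read by resazurin assay, with a stated time of 48 h; on this read-out higher numbers stand for lower toxicity in this test and lower numbers for higher toxicity in this test:
Compound 1 `O=S(=O)(Nc1ccc2oc(-c3ccccc3)nc2c1)c1cccc(F)c1` gives 68000 nM.
Compound 2 `O=S(=O)(Nc1ccc(-c2nc3ccccc3o2)cc1)c1cccc(O)c1` gives only a limit of the assay, > 100000 nM.
Compound 3 `C=Cc1ccc(S(=O)(=O)Nc2ccc(-c3nc4ccccc4o3)cc2)cc1` also gives only a limit of the assay, > 100000 nM.

Going by the values given here, compound 1 stands as the only compound of the three with a number; the other two sit at the limit of > 100000 nM in this assay, at which 2 of the 3 values shown sit, and cannot be placed relative to it beyond that. Among the compounds with values here, the single step that can be drawn among the measured compounds, a step that the two limits leave unreadable from compound 2 to compound 3, runs between two limits, so its size is not readable and it gives no scale for any change.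

Compound 4 `CS(=O)(=O)Nc1ccc2oc(-c3ccccc3)nc2c1` is the compound still to be measured. It differs from compound 1 by methyl in place of 3-fluorophenyl on a sulfonyl sulfur. Within the data shown here, no measured step bears on this change: the only measured step on the sulfonyl sulfur swaps a different pair of groups and is itself unreadable. With nothing to read from, no step beyond the scatter in this assay is expected in either direction, and the central expectation stays near the value of compound 1, with a wide range that reaches the limit seen for compound 2 and compound 3.

Compound 4 is therefore expected at 80000 nM, within 30000 nM to 200000 nM.
That corresponds to an expected step of a 1.2-fold higher number from compound 1 to compound 4 (0.07 log units; within the scatter).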

Compound 4, half-maximal cytotoxic concentration: > 100000 nM
Compound 4 ended at the assay's limit; the forecaster's own chance of this, stated with the estimate: 45%; at least 1.2-fold (0.09 log units) between middle value and limit.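

In this assay, going by these compounds alone, replacing 3-fluorophenyl with methyl on a sulfonyl sulfur gives an at least 1.4-fold higher number from compound 1 to compound 4 (0.16 log units; that floor lies within the scatter), the first step at this position with any readable size, since the earlier step on the sulfonyl sulfur cannot be read. Even so, the change shows no shift beyond the scatter, and the result shows only that a sulfonyl sulfur carrying methyl, with no ring, does not give a number in this test on the core of compound 1. The reading for compound 4 is a limit and not a number, so the step has a floor but no upper end, and its true size stays unknown: the limit of > 100000 nM in this assay, at which 3 of the 4 values shown sit.

Open, from the compounds shown here alone, is whether any other group on the sulfonyl sulfur of this core, such as a longer chain like butyl, an amine or a carboxylic acid, would give a number rather than a limit in this assay. Also open is whether the number of compound 1 belongs to 3-fluorophenyl specifically, as the series shown holds no second aromatic group on this sulfur of the same core for comparison.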